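A few compounds are considered here, and "the series" means these few. Any claim that something is new, unique, unknown or untested is made for them only; others in the source may bear on it.

For the measured compounds named here, in a functional assay on SW-620 cells (Homo sapiens) for inhibition, read by sulforhodamine B assay, with a stated time of 48 h, tested at 10 uM (on this read-out lower numbers stand for a stronger effect and higher numbers for a weaker effect at the one concentration tested), compound 1 `COc1cc(Cl)cc(-c2nn(-c3cccc(NC(=O)c4ccc(Cl)c(Cl)c4)c3)cc2-c2ccncc2)c1` gives 84.2%, the highest of the three numbers measured so far. Compound 3 `COc1cc(Cl)cc(-c2nn(-c3cccc(NC(=O)Nc4cc(C(F)(F)F)cc(C(F)(F)F)c4)c3)cc2-c2ccncc2)c1` gives 7.18% and compound 2 `O=C(Nc1cccc(-n2cc(-c3ccncc3)c(-c3cc(O)cc(Cl)c3)n2)c1)Nc1ccc(Cl)c(Cl)c1` gives -33.8%; both numbers lie far below that of compound 1, beyond the scatter of the read-out. Compound 4 `COc1cc(Cl)cc(-c2nn(-c3cccc(NC(=O)Nc4ccc(Cl)c(Cl)c4)c3)cc2-c2ccncc2)c1` has not yet been measured. It differs from compound 1 in one place: (3,4-dichlorophenyl)amino in place of 3,4-dichlorophenyl on a carbonyl carbon. Compound 2 carries the same ((3,4-dichlorophenyl)carbamoyl)amino group that enters here, and compound 3 a related carbamoyl-type linkage. A large downward step is expected because compound 2 gives -33.8% and compound 3 gives 7.18%. The estimated step is a number 84.2 percentage points lower from compound 1 to compound 4 (beyond the scatter), well beyond the scatter. Compound 4 is therefore expected to give about 0%, within a range from -40% to 40%.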

Compound 4, a percentage reported as activity, at one concentration (the size of the read-out at that concentration, not a potency): 13.3%
Compound 4: middle estimate off by 13.3 percentage points, on the low side; measured number inside the range.
By their numbers in this assay, from the lowest: compound 2; then compounds 3 and 4 (each within the scatter of the next); then compound 1.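

In this assay, (3,4-dichlorophenyl)amino in place of 3,4-dichlorophenyl on a carbonyl carbon is, as a single change, enough for a number 70.9 percentage points lower from compound 1 to compound 4 (beyond the scatter). With that group held constant, methyl in place of hydrogen on an oxygen on an aromatic ring gives a number 47.1 percentage points higher from compound 2 to compound 4 (beyond the scatter), so this second site also moves the read-out. No measured evidence here explains either step. Going by these compounds, it remains open how a methylamino or piperidinyl group on that carbonyl carbon would compare, or an ethyl group on that oxygen.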